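Bromo for hydrogen on the benzamide ring of compound 3

A few compounds are considered here, and "the series" means these few. Any claim that something is new, unique, unknown or untested is made for them only; others in the source may bear on it.

Measured so far:
- compound 1, `COc1cc(OCC(=O)Nc2cccc(NC(=O)c3ccc(N(C)C)cc3)c2)ccc1C=O`: 3740 nM
- compound 2, `Cc1c(OCC(=O)Nc2cccc(NC(=O)c3ccc(N(C)C)cc3)c2)ccc2c(=O)ccoc12`: > 10000 nM
- compound 3, `O=C(COc1ccc2c(=O)ccoc2c1)Nc1cccc(NC(=O)c2ccccc2)c1`: 120 nM

Of the compounds shown here, three have been read in an assay on isolated protein for inhibition of Rho-associated protein kinase 1 (Homo sapiens), read by scintillation counting, radiometric assay and 33P incorporation, with a stated time of 40 min, in the presence of a further agent that is not named here; on this read-out lower numbers stand for stronger inhibition and higher numbers for weaker inhibition. Compound 1 `COc1cc(OCC(=O)Nc2cccc(NC(=O)c3ccc(N(C)C)cc3)c2)ccc1C=O` gives 3740 nM in this assay. For compound 2 `Cc1c(OCC(=O)Nc2cccc(NC(=O)c3ccc(N(C)C)cc3)c2)ccc2c(=O)ccoc12` this assay reports only a limit, > 10000 nM, and no number (the limit of > 10000 nM in this assay, at which 1 of the 3 values shown sits). Compound 3 `O=C(COc1ccc2c(=O)ccoc2c1)Nc1cccc(NC(=O)c2ccccc2)c1` gives 120 nM in this assay, the lowest of the two numbers shown; its nearest neighbour is compound 1, whose number is higher by a margin that lies beyond the scatter. For the measured compounds named here, compound 1 and compound 3 differ in more than one place, so no single step between them is counted.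

The next compound, compound 4 `O=C(COc1ccc2c(=O)ccoc2c1)Nc1cccc(NC(=O)c2ccc(Br)cc2)c1`, keeps the whole frame of compound 3 and changes one thing: bromo in place of hydrogen on an aromatic carbon, para to a large group. Going by the values given here, no measured pair here shows this change on its own, so there is no step to lean on. The account expects a small step from compound 3 to compound 4 in this assay, a 1.3-fold higher number from compound 3 to compound 4 (0.10 log units; within the scatter), in no clear direction and most likely within the scatter. Compound 4 is therefore estimated at 150 nM in this assay, with a range from 40 nM to 600 nM.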

Compound 4, half-maximal inhibitory concentration: 303 nM
Estimate against measurement, compound 4: 2.0-fold (0.31 log units) below; the range from low to high includes it.
By their numbers in this assay, from the lowest: compound 3; then compound 4; then compound 1. At a limit, above all of these: compound 2.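

The benzamide ring had not been changed on its own before, and this single exchange of bromo for hydrogen on an aromatic carbon, para to a large group, gives a 2.5-fold higher number from compound 3 to compound 4 (0.40 log units; beyond the scatter) in this assay for one added heavy atom. The step is modest but lies beyond the scatter, so this position is not indifferent to the change, although compound 4 with its bromo still gives 303 nM in this read-out and inhibition is kept. Nothing measured here bears on why the number moves in this direction.

One group at one place cannot show whether the step belongs to bromo itself or would come with any group put there, such as fluoro, chloro, methoxy, an amine or a carboxylic acid. From the compounds shown here alone, it also remains open whether bromo on another aromatic carbon of the same ring would give a step of similar size, or whether the step from hydrogen to bromo would carry over to a compound with a different core.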